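Methoxy on the anilino ring: a small change

The compounds below may be only part of what the source reports. "The series", "measured", "known", "first", "only" and "open" are said of these compounds alone.

Measured compounds:
compound 1, `Cc1nc(SCC(=O)Nc2nc(-c3ccc(Cl)cc3)cs2)n(Nc2ccccc2)c1C` — 3480 nM
compound 2, `Cc1ccc(Nn2c(SCC(=O)Nc3nc(-c4ccccc4)cs3)nc(C)c2C)cc1` — 2810 nM

Both compounds share a core in which a thioether-linked amide joins a substituted aminothiazole. In a functional assay on SNB-75 cells (Homo sapiens) for antiproliferative activity, read by sulforhodamine B assay, with a stated time of 48 h (a higher number here means a weaker inhibitor of growth, a lower number a stronger inhibitor of growth), compound 1 gives 3480 nM, and compound 2 gives 2810 nM. On these numbers compound 1 stands at one end of a very short range; its distance from compound 2 lies within the scatter, so the two cannot be told apart by this assay. For the measured compounds named here, compound 2 differs from compound 1 in two places at once, so no single step between measured compounds can be read off.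

Compound 3, `COc1ccc(Nn2c(SCC(=O)Nc3nc(-c4ccc(Cl)cc4)cs3)nc(C)c2C)cc1`, has not yet been measured. It differs from compound 1 by one change: methoxy in place of hydrogen on an aromatic carbon. Going by the values given here, the only comparison available, compound 1 against compound 2, shows that varying the anilino ring and the phenyl on the thiazole together leaves the number essentially unchanged. Without a cleaner precedent, the expectation for this assay is a step no larger than the scatter, in no firm direction. Compound 3 is therefore estimated at 3000 nM, with a range from 1200 nM to 8000 nM, which corresponds to an expected step of a 1.2-fold lower number from compound 1 to compound 3 (0.06 log units; within the scatter).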

Compound 3, concentration for 50% growth inhibition: 4800 nM
Estimate against measurement, compound 3: 1.6-fold (0.20 log units) below; low and high end bracket the measured number.
By their numbers in this assay, from the lowest: compounds 2, 1 and 3 (each within the scatter of the next).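

The change from hydrogen to methoxy on the anilino ring, para to a large group, gives a 1.4-fold higher number from compound 1 to compound 3 (0.14 log units; within the scatter) in this assay. For the compounds shown here, compound 1 and compound 3 differ in this one place, so this is the first comparison here that isolates a single change, and it shows that this methoxy, with its 2 heavy atoms, produces no difference that this assay can distinguish from the usual scatter of repeated measurements. No measured information about the compounds is available to explain this result.

From the compounds shown here alone, this single methoxy result says little about other groups at the same position, so it remains open whether an amine, a carboxylic acid or a longer chain such as butoxy would also leave the number within the scatter. Going by these compounds, compound 2 differs from compound 1 and from compound 3 in more than one place, so its steps to them cannot be read, and the contribution of each separate difference remains open.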